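The compounds below may be only part of what the source reports. "The series", "measured", "known", "first", "only" and "open" are said of these compounds alone.

Compound 1 `CC(C)(C)C#Cc1cc(N(C(=O)[C@H]2CC[C@H](C)CC2)[C@H]2CC[C@H](Oc3ccccn3)CC2)c(C(=O)O)s1` gives > 20000 nM in an ADME assay on MT4 cells (Homo sapiens) for cytotoxicity, with a stated time of 5 days (on this read-out lower numbers stand for higher toxicity in this test and higher numbers for lower toxicity in this test), a limit of the assay.
Compound 2 `CC(C)(C)C#Cc1cc(N(C(=O)[C@H]2CC[C@H](C)CC2)[C@H]2CC[C@H](OC3CCOC3)CC2)c(C(=O)O)s1` gives > 20000 nM in this assay, likewise a limit of the assay.

For the measured compounds named here, compound 2 therefore stands at the limit of > 20000 nM in this assay, at which 2 of the 2 values shown sit, and the one measured step, a step that the two limits leave unreadable from compound 1 to compound 2, cannot be read because both of its ends are limits. Compound 3 `CC(C)(C)C#Cc1cc(N(CCO)C(=O)[C@H]2CC[C@H](C)CC2)c(C(=O)O)s1` is not yet measured. It differs from compound 2 by 2-hydroxyethyl in place of 4-((oxolan-3-yl)oxy)cyclohexyl on an amide-type nitrogen. Going by the values given here, no measured step touches this amide-type nitrogen, so no step bears directly on the change, and the one step that exists gives no size at all. On these numbers compound 3 is expected to sit near or at the same limit, with the step that the limit leaves unreadable from compound 2 to compound 3 estimated as no more than the usual scatter. Compound 3 is thus estimated at 25000 nM, between 8000 nM and 80000 nM, most likely again reported only as a limit.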

Compound 3, half-maximal cytotoxic concentration: > 20000 nM
Compound 3: a limit, no number; the forecaster's own chance of this, stated with the estimate: 75%; the middle value does not contradict the limit.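

Compound 3 gives > 20000 nM in this assay, again a limit of the assay, so no size can be read for its change from compound 2, whose value is also a limit. The compounds shown leave open whether changes on the amide-type nitrogen alter cytotoxicity at all, since all three values are limits: the limit of > 20000 nM in this assay, at which 3 of the 3 values shown sit.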